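Compound 1 to compound 4: methoxy to methoxycarbonyl

The source may hold more compounds than are shown below. What is called first, only, known or untested is meant among the compounds shown, and "the series" means these compounds.

Values in a functional assay on KB cells (Homo sapiens) for antiproliferative activity; on this read-out higher numbers stand for weaker inhibition and lower numbers for stronger inhibition
compound 1 `COc1ccc(Nc2cccc3c2N(S(=O)(=O)c2ccc(OC)cc2)CC3)cc1` gives 1200 nM
compound 2 `COc1ccc(S(=O)(=O)N2CCc3cccc(Nc4ccc(F)c(F)c4)c32)cc1` gives 412 nM
compound 3 `COc1ccc(S(=O)(=O)N2CCc3cccc(Nc4ccc(C#N)cc4)c32)cc1` gives 49.7 nM

Compound 1 has the highest number of the three, 1200 nM in this assay. Compound 4 `COC(=O)c1ccc(Nc2cccc3c2N(S(=O)(=O)c2ccc(OC)cc2)CC3)cc1` carries methoxycarbonyl in place of methoxy on an aromatic carbon, para to a large group (methoxycarbonyl in place of methoxy on an aromatic carbon). Within the data shown here, two measured steps bear on this change. The closest replaces the same methoxy with cyano and gives a 24-fold lower number from compound 1 to compound 3 (1.38 log units; beyond the scatter), a large step. The 3,4-difluorophenyl swap gives a 2.9-fold lower number from compound 1 to compound 2 (0.46 log units; beyond the scatter), a modest one. Neither new group is methoxycarbonyl, so only a modest drop is expected, and its size is uncertain. The estimated step is a 6.0-fold lower number from compound 1 to compound 4 (0.78 log units; beyond the scatter). For compound 4 the expected value is 200 nM, with an estimated range of 50 nM to 800 nM.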

Compound 4, half-maximal inhibitory concentration: 93.5 nM
Estimate against measurement, compound 4: 2.1-fold (0.33 log units) above, within the range that was stated.
By their numbers in this assay, from the lowest: compounds 3 and 4 (each within the scatter of the next); then compound 2; then compound 1.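

In this assay, methoxycarbonyl on the aromatic carbon para to a large group gives a 13-fold lower number from compound 1 to compound 4 (1.11 log units; beyond the scatter), so a large step away from methoxy is not unique to cyano. Exchanging cyano for methoxycarbonyl gives a 1.9-fold higher number from compound 3 to compound 4 (0.27 log units; within the scatter), and these two groups cannot be separated on this read-out. The 4-(methoxycarbonyl)phenyl group also improves on 3,4-difluorophenyl, with a 4.4-fold lower number from compound 2 to compound 4 (0.64 log units; beyond the scatter). On these data alone, whether a carboxylic acid or a primary amide at this place would keep numbers this low remains open. No available evidence explains these steps.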